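Adding a second chloro to a weak piperidinedione-piperazine series

The source may hold more compounds than are shown below. What is called first, only, known or untested is meant among the compounds shown, and "the series" means these compounds.

Three analogues share one core and differ only in the aryl group on the piperazine. In a functional assay on the whole organism (strain CD-1) with Mus musculus as the target, with a stated time of 2 h (a higher number here means that more compound is needed for the effect, a lower number that less compound is needed), compound 1 `CC1(c2ccccc2)CC(=O)N(CC(=O)N2CCN(c3ccccc3F)CC2)C1=O` gives 300 mg/kg. Compound 2 `CC1(c2ccccc2)CC(=O)N(CC(=O)N2CCN(c3cccc(Cl)c3)CC2)C1=O` shows no single number, since in this assay compound 2 is reported as "not active" (no number reported). Compound 3 `COc1ccccc1N1CCN(C(=O)CN2C(=O)CC(C)(c3ccccc3)C2=O)CC1` likewise stands without a number, being "not active" (no number reported) in this assay. Compound 4 `CC1(c2ccccc2)CC(=O)N(CC(=O)N2CCN(c3cccc(Cl)c3Cl)CC2)C1=O` has not yet been tested. Compound 4 differs from compound 2 by chloro in place of hydrogen on an aromatic carbon. Among the compounds with values here, no measured pair tells how such a change moves this assay, so the direction of any step is unknown and it may stay within the scatter. For compound 4 the expected value in this assay is 300 mg/kg, with a range from 100 mg/kg to 1000 mg/kg, and a real chance that no number is obtained.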

Compound 4, minimum effective dose: "not active" (no number reported)
The entry for compound 4 holds no number; no gap can be computed for the estimate.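

Compound 2 and compound 4 are both reported as not active in this assay, so no step can be read between them. The compounds shown leave open whether the second chloro changes the dose needed. Nothing measured here offers an explanation.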